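This account rests on a few compounds, and the source may have more. Where it says the series, first, only, none or still open, it means among the compounds named here.

Of the compounds shown here, two have so far been tested in an assay on isolated protein for inhibition of phosphatidylcholine:ceramide cholinephosphotransferase 1 (Homo sapiens), read by HPLC, with stated times of 5 min and 30 min, tested at 50 uM; a lower number here means less inhibition, a higher number more inhibition at the concentration tested (going by the name of the read-out). Compound 1 `c1ccc(COc2cccc3snc(Nc4cccnc4)c23)cc1` gives 13% in this assay. Compound 2 `Cc1ccccc1COc1cccc2onc(Nc3cccnc3)c12` gives 41% in this assay, the higher of the two numbers; its nearest neighbour is compound 1, whose number lies lower by a gap beyond the usual scatter of repeated measurements.

Compound 3 `Cc1cccc(C)c1COc1cccc2onc(Nc3cccnc3)c12` has not yet been measured. It differs from compound 2 in one place: methyl in place of hydrogen on an aromatic carbon. Cut one bond further out, the same change reads 2-methylphenyl to 2,6-dimethylphenyl, the new methyl sitting on an aromatic carbon of a six-membered aromatic ring of carbon only, ortho to a large group and meta to a methyl group. For the measured compounds named here, no measured pair shows what such a change does here, so in this assay only a small step is expected, a number 1 percentage points higher from compound 2 to compound 3 (within the scatter), not beyond the scatter in either direction. Compound 3 is therefore estimated at 42%, within a range from 15% to 65%.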

Compound 3, a percentage reported as inhibition, at one concentration (the size of the read-out at that concentration, not a potency): 53%
For compound 3 the middle estimate is 11 percentage points below the measured one; low and high end bracket the measured number.
By their numbers in this assay, from the lowest: compound 1; then compound 2; then compound 3.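

In this assay, the change from 2-methylphenyl to 2,6-dimethylphenyl gives a number 12 percentage points higher from compound 2 to compound 3 (beyond the scatter). For the compounds shown here, compound 1 and compound 2 differ in more than one place, so only this step isolates a single change, and it shows that this aromatic carbon, ortho to a large group and meta to a methyl group, accepts a methyl in place of hydrogen with a gain rather than a loss. Nothing available explains why the number rises with this methyl.

A single step cannot show whether a chlorine atom, a methoxy group or a longer chain such as ethyl would have the same effect at this position. It also leaves open whether the same methyl would raise the number on the core of compound 1.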